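The compounds below may be only part of what the source reports. "The series", "measured", "known", "first", "only" and "open" are said of these compounds alone.

In a functional assay on QGY-7703 cells (Homo sapiens) for cytotoxicity, read by MTT assay, with a stated time of 24 h (on this read-out higher numbers stand for weaker inhibition and lower numbers for stronger inhibition), compound 1 (`CN1C/C(=C\c2ccc(C(F)(F)F)cc2)C(=O)/C(=C/c2cccnc2)C1`) gives 1660 nM, compound 2 (`O=C1/C(=C/c2cccnc2)CN(S(=O)(=O)c2ccccc2)C/C1=C\c1ccccc1F`) gives 4800 nM and compound 3 (`O=C1/C(=C/c2ccncc2)CN(S(=O)(=O)c2ccccc2)C/C1=C\c1ccccc1F`) gives 8400 nM. Compound 3 therefore sits with compound 2 at the weak end of this small set, while the number for compound 1 is clearly lower. Next comes compound 4 (`O=C1/C(=C/c2ccncc2)CN(S(=O)(=O)c2ccc(F)cc2)C/C1=C\c1ccccc1F`), which differs from compound 3 in one place: fluoro in place of hydrogen on an aromatic carbon. Its phenylsulfonyl group thus becomes a (4-fluorophenyl)sulfonyl group. Among the compounds with values here, the only measured step between close relatives, a 1.8-fold higher number from compound 2 to compound 3 (0.24 log units; within the scatter), swaps pyridin-3-yl for pyridin-4-yl and stays within the scatter. Within the data shown here, that step leaves the phenylsulfonyl group untouched, so it bears on the new change only indirectly, and no measured pair shows what a fluoro does at this place. With so little to go on, no step beyond the scatter is expected in this assay. The expected change is an estimated 1.2-fold lower number from compound 3 to compound 4 (0.08 log units; within the scatter). For compound 4 the estimated value is 7000 nM, with an expected range from 3000 nM to 15000 nM.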

Compound 4, half-maximal inhibitory concentration: 9100 nM
Compound 4: the middle estimate sits 1.3-fold (0.11 log units) below what was measured; measured number inside the range.
By their numbers in this assay, from the lowest: compound 1; then compounds 2, 3 and 4 (each within the scatter of the next).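

Swapping hydrogen for fluoro on the phenylsulfonyl group in this assay gives a 1.1-fold higher number from compound 3 to compound 4 (0.03 log units; within the scatter) and so leaves compound 3 and compound 4 indistinguishable. Within the data shown here, this is the first measured pair to change the phenylsulfonyl group, and it shows that a single fluoro, placed on an aromatic carbon para to a large group, produces no step beyond the scatter. No measured evidence bears on why this is so.

Going by these compounds, whether an amine, a methoxy group or a carboxylic acid at this same place would also stay within the scatter remains open, as does the effect of this fluoro alongside the pyridin-3-yl group of compound 2. Compound 1, at 1660 nM in this assay, differs from these compounds in more than one place, so its value cannot be tied to any single group.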